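From compound 1 to compound 3: a 4-methoxyphenoxy swap

This account rests on a few compounds, and the source may have more. Where it says the series, first, only, none or still open, it means among the compounds named here.

For the measured compounds named here, in an ADME assay on cells (Homo sapiens) for cytotoxicity, read by resazurin assay, with a stated time of 5 days (a lower number here means that less compound is tolerated, a higher number that more compound is tolerated), compound 1 `O=S(=O)(Cc1nc(-c2ccc(Cl)nc2)c2sccc2n1)c1cccc(Cl)c1` gives 70000 nM, the only actual number so far. Compound 2 `COc1ccc(-c2nc(C(F)S(=O)(=O)c3cccc(Cl)c3)nc3ccsc23)cn1` is reported only as a limit, > 50000 nM. Compound 3 `COc1ccc(Oc2nc(CS(=O)(=O)c3cccc(Cl)c3)nc3ccsc23)cc1` carries 4-methoxyphenoxy in place of 6-chloropyridin-3-yl on an aromatic carbon next to the ring nitrogen (4-methoxyphenoxy in place of 6-chloropyridin-3-yl on an aromatic carbon). Going by the values given here, no measured step covers this change, so the expectation rests on compound 1 at 70000 nM alone. The expected change is small and downward, a 1.8-fold lower number from compound 1 to compound 3 (0.24 log units; within the scatter), and stays within the usual scatter of this assay. For compound 3 the estimated value is 40000 nM, with an expected range of 10000 nM to 100000 nM.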

Compound 3, half-maximal cytotoxic concentration: > 50000 nM
Compound 3 ended at the assay's limit (the forecaster's own chance of this, stated with the estimate: 40%); middle value at least 1.2-fold (0.09 log units) away from the limit.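

No step from compound 1 to compound 3 can be read, because compound 3 is reported only as a limit and not as a number: the limit of > 50000 nM in this assay, at which 2 of the 3 values shown sit.

Going by these compounds, whether 4-methoxyphenoxy in place of 6-chloropyridin-3-yl changes the tolerated concentration at all stays open.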